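Removing a Ring Chlorine from a Bradykinin B1 Antagonist

The compounds below may be only part of what the source reports. "The series", "measured", "known", "first", "only" and "open" are said of these compounds alone.

Compounds measured so far:
Compound 1 `Cc1nc(-c2c(F)cc(Cl)cc2-c2cnc([C@@H](C)NC(=O)N(C)O)c(F)c2)no1` gives 1.2 nM in a functional assay on IMR-90 cells for antagonist activity at B1 bradykinin receptor (Homo sapiens), read by calcium flux; on this read-out higher numbers stand for weaker inhibition and lower numbers for stronger inhibition.
Compound 2 `Cc1nc(-c2c(F)cc(Cl)cc2-c2cnc(CNC(=O)N(C)O)c(F)c2)no1` gives 17 nM in this assay.

Within the data shown here, of the two numbers in hand, compound 1 holds the lower one, and its only neighbour is compound 2, reached by a step that is a 14-fold higher number from compound 1 to compound 2 (1.15 log units; beyond the scatter) through hydrogen in place of methyl on a saturated chain carbon bound to an amide-type nitrogen and an aromatic carbon.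

Compound 3 `Cc1nc(-c2c(F)cccc2-c2cnc([C@@H](C)NC(=O)N(C)O)c(F)c2)no1` is the untested member. It differs from compound 1 by hydrogen in place of chloro on an aromatic carbon. Among the measured compounds shown here, no measured step touches this chloro group, so the single known step gives no guide here. A change of one heavy atom on the shared core is expected to shift the number only modestly, most likely toward weaker inhibition. Compound 3 is therefore estimated at 3.5 nM, within 1.2 nM to 12 nM, a step of a 2.9-fold higher number from compound 1 to compound 3 (0.46 log units; beyond the scatter) that is expected.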

Compound 3, half-maximal inhibitory concentration: 31 nM
Compound 3: the middle estimate sits 8.9-fold (0.95 log units) below what was measured; measured number outside the range, above it.
By their numbers in this assay, from the lowest: compound 1; then compounds 2 and 3 (each within the scatter of the next).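

In this assay, the chloro group on this aromatic carbon, para to a 5-methyl-1,2,4-oxadiazol-3-yl group, proves important: putting hydrogen in its place gives a 26-fold higher number from compound 1 to compound 3 (1.41 log units; beyond the scatter), a large move toward weaker inhibition from the change of a single heavy atom. The earlier step, a 14-fold higher number from compound 1 to compound 2 (1.15 log units; beyond the scatter), concerned only the methyl on the chain, so two separate places on compound 1 are now each seen to influence inhibition. Nothing measured here gives a reason for the drop seen on removing the chlorine.

On these data alone, it remains open whether chlorine in particular is needed or whether another group at this position, such as bromo, methoxy or a nitrile, would restore inhibition. Also open, as far as these compounds go, is how a compound lacking both the chloro group and the chain methyl would behave.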